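Exchanging the Ketone Ring of Compound 2

A few compounds are considered here, and "the series" means these few. Any claim that something is new, unique, unknown or untested is made for them only; others in the source may bear on it.

Compound 1 `Cc1ccccc1C(=O)c1cnc(Nc2cccc(C(F)(F)F)c2)s1`: 63 nM in an assay for inhibition of Neuropeptide Y receptor type 5 (Mus musculus); on this read-out higher numbers stand for weaker inhibition and lower numbers for stronger inhibition
Compound 2 `CCc1ccccc1C(=O)c1cnc(Nc2cccc(C(F)(F)F)c2)s1`: 32 nM in this assay

For the measured compounds named here, compound 2 has the lowest of the two numbers so far, and the only measured step, a 2.0-fold lower number from compound 1 to compound 2 (0.29 log units; within the scatter), is within the scatter. Compound 3 `Cc1cc(C(=O)c2cnc(Nc3cccc(C(F)(F)F)c3)s2)c(C)s1` carries 2,5-dimethylthiophen-3-yl in place of 2-ethylphenyl on a carbonyl carbon. Going by the values given here, no measured step exchanges one ring for another here, so the one known step says little about this change; the expectation is a small shift, a 1.3-fold higher number from compound 2 to compound 3 (0.10 log units; within the scatter), not beyond the scatter. Compound 3 is therefore estimated at 40 nM in this assay, with a range from 12 nM to 130 nM.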

Compound 3, half-maximal inhibitory concentration: 395 nM
Compound 3: middle estimate off by 9.9-fold (0.99 log units), on the low side; the measured number lies above the stated range.
By their numbers in this assay, from the lowest: compounds 2 and 1 (each within the scatter of the next); then compound 3.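

Unlike the earlier step, which stayed within the scatter, this exchange of one aromatic ring for another goes beyond it: 2,5-dimethylthiophen-3-yl in place of 2-ethylphenyl gives a 12-fold higher number from compound 2 to compound 3 (1.09 log units; beyond the scatter) in this assay and in place of 2-methylphenyl gives a 6.3-fold higher number from compound 1 to compound 3 (0.80 log units; beyond the scatter) as well. So the group on this carbonyl carbon can change the number strongly. No measured evidence accounts for the loss.

A plain thiophen-3-yl group would help separate the part played by the ring from that of its two methyl groups. From the compounds shown here alone, whether a pyridin-3-yl ring or a 2-propylphenyl group would keep the low number of compound 2 also stays open.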